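The source may hold more compounds than are shown below. What is called first, only, known or untested is meant among the compounds shown, and "the series" means these compounds.

Measured so far:
- compound 1, `COc1cccc(Cn2cnc3sc(-c4ccc5[nH]ncc5c4)cc3c2=O)c1`: 20 nM
- compound 2, `COc1cccc(Cn2cnc3sc(-c4ccncc4)cc3c2=O)c1`: 45 nM
- compound 3, `COc1cccc(Cn2cnc3sc(-c4ccnc(OC)c4)cc3c2=O)c1`: > 10000 nM

The three compounds share one core and differ only in the aromatic group attached next to the ring sulfur. In an assay on isolated protein for inhibition of Rho-associated protein kinase 1 (Homo sapiens), read by radiometric assay and 33P incorporation, with a stated time of 40 min, in the presence of a further agent that is not named here (a lower number here means a stronger inhibitor, a higher number a weaker inhibitor), compound 1 gives 20 nM, the lowest of the two plain numbers shown. Compound 2 gives 45 nM in this assay, and the step of a 2.3-fold higher number from compound 1 to compound 2 (0.35 log units; beyond the scatter). The value of compound 3 in this assay is a limit, > 10000 nM; one of the three values sits at this limit (the limit of > 10000 nM in this assay, at which 1 of the 3 values shown sits). From that follow an at least 500-fold higher number from compound 1 to compound 3 (2.69 log units; beyond the scatter) and an at least 220-fold higher number from compound 2 to compound 3 (2.34 log units; beyond the scatter).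

Compound 4 is `COc1cccc(Cn2cnc3sc(-c4ccnc(N)c4)cc3c2=O)c1`. Relative to compound 1 the change is 2-aminopyridin-4-yl in place of 1H-indazol-5-yl on an aromatic carbon. Among the compounds with values here, two measured steps bear on it: the move to the bare pyridine cost little in compound 2, while adding methoxy to that pyridine in compound 3 cost a great deal. An amino group in the same position is a different substituent, so the outcome is uncertain, but some loss against compound 1 is expected, a 4.5-fold higher number from compound 1 to compound 4 (0.65 log units; beyond the scatter). Compound 4 is therefore estimated at 90 nM, with a likely range from 15 nM to 600 nM.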

Compound 4, half-maximal inhibitory concentration: 18 nM
For compound 4 the middle estimate is 5.0-fold (0.70 log units) above the measured one; the range from low to high includes it.
By their numbers in this assay, from the lowest: compounds 4 and 1 (each within the scatter of the next); then compound 2. At a limit, above all of these: compound 3.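

In this assay, 2-aminopyridin-4-yl serves as well as 1H-indazol-5-yl next to the ring sulfur, with a 1.1-fold lower number from compound 1 to compound 4 (0.05 log units; within the scatter), so the two-ring group is not required for this level of inhibition in this series. The pyridine can also carry an added group without a loss: amino in place of hydrogen gives a 2.5-fold lower number from compound 2 to compound 4 (0.40 log units; beyond the scatter), so the collapse seen with methoxy does not extend to every added group. Amino in place of methoxy gives an at least 550-fold lower number from compound 3 to compound 4 (2.74 log units; beyond the scatter), and the value of compound 3 behind this step is a limit: the limit of > 10000 nM in this assay, at which 1 of the 4 values shown sits.

From the compounds shown here alone, whether this result is particular to the amino group stays open, since a methylamino, dimethylamino or hydroxy group in its place would be needed to show that. Going by these compounds, it is also open whether methyl or fluoro would behave like amino or like methoxy.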